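The source may report more compounds than this note shows. Statements on the series, on what has been measured and on what is new or still open speak of the compounds shown alone.

Measured so far in an ADME assay on cells (Homo sapiens) for cytotoxicity, read by polymerase chain reaction, with a stated time of 3 days; a lower number here means that less compound is tolerated, a higher number that more compound is tolerated:

Compound 1, `Nc1nc(Cl)c(-c2nc3ccccc3o2)c(N[C@@H]2C[C@H](CO)[C@@H](O)[C@H]2O)n1`, gives 12000 nM.
Compound 2, `Nc1nc(Cl)c(-c2nc3ccccc3s2)c(N[C@@H]2C[C@H](CO)[C@@H](O)[C@H]2O)n1`, gives 14000 nM.
Compound 3, `Cc1nc(N)nc(N[C@@H]2C[C@H](CO)[C@@H](O)[C@H]2O)c1-c1nc2ccccc2s1`, gives 4000 nM.

Compound 3 stands lowest of the three numbers in this assay, so less of it is tolerated than of the other two. Its nearest neighbour is compound 1, and the gap to compound 2 is the step of a 3.5-fold lower number from compound 2 to compound 3 (0.54 log units; beyond the scatter), which is beyond the scatter. The other step, a 1.2-fold higher number from compound 1 to compound 2 (0.07 log units; within the scatter), lies within the scatter.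

Compound 4, `COCCNc1nc(C)c(-c2nc3ccccc3s2)c(N[C@@H]2C[C@H](CO)[C@@H](O)[C@H]2O)n1`, differs from compound 3 in one place: 2-methoxyethyl in place of hydrogen on a nitrogen on an aromatic ring. Neither of the measured steps touches this nitrogen on the aromatic ring; one exchanges the ring system on an aromatic carbon, the other exchanges chloro for methyl. Nothing measured therefore speaks directly to this change, and the expectation is a step of a 1.1-fold higher number from compound 3 to compound 4 (0.05 log units; within the scatter), that is, no movement beyond the scatter. Compound 4 is estimated at 4500 nM, in the range 1500 nM to 13000 nM.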

Compound 4, half-maximal cytotoxic concentration: 21000 nM
Beside the measured number, compound 4's estimate is 4.7-fold (0.67 log units) below it, and the stated range ends below it.
By their numbers in this assay, from the lowest: compound 3; then compounds 1, 2 and 4 (each within the scatter of the next).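

Setting 2-methoxyethyl in place of hydrogen on the nitrogen on the aromatic ring gives a 5.3-fold higher number from compound 3 to compound 4 (0.72 log units; beyond the scatter) in this assay, so a change at this nitrogen can move the number beyond the scatter, towards more compound being tolerated. For the compounds shown here, the earlier steps touched only aromatic carbons, which makes this the sole reading for the change from amino to (2-methoxyethyl)amino, and it runs opposite to the lower number seen for methyl in place of chloro. No measurement at hand accounts for the direction or size of this step.

On these data alone, it stays open whether the rise belongs to the 2-methoxyethyl group itself or would follow from other groups on this nitrogen, such as a plain ethyl, a longer chain or an amine. As far as these compounds go, it is also open whether the same change on compound 2, which carries chloro, would give a step of similar size.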